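The source may report more compounds than this note shows. Statements on the series, on what has been measured and on what is new or still open speak of the compounds shown alone.

Among the measured compounds shown here, compound 3 `CSc1ccc(NC(=O)Nc2cc(C)nc3ccccc23)cc1` carries the only number in the set so far: in an ADME assay on HEK293 cells (Homo sapiens) for cytotoxicity, with a stated time of 72 h (on this read-out higher numbers stand for an effect only at larger amounts of compound and lower numbers for an effect already at smaller amounts), compound 3 gives 24000 nM. Compound 1 `Cc1cc(NC(=O)Nc2ccc(C(=O)O)cc2)c2ccccc2n1` reaches only the limit > 25000 nM in this assay. Compound 2 `CC(=O)c1ccc(NC(=O)Nc2cc(C)nc3ccccc23)cc1` likewise stops at the limit > 25000 nM. Two of three values thus sit at the limit of > 25000 nM in this assay, at which 2 of the 3 values shown sit. The steps of an at least 1.0-fold lower number from compound 1 to compound 3 (0.01 log units; that floor lies within the scatter) and an at least 1.0-fold lower number from compound 2 to compound 3 (0.01 log units; that floor lies within the scatter) are floors lying within the scatter, and a step that the two limits leave unreadable from compound 1 to compound 2 cannot be read at all. Compound 4 `Cc1cc(NC(=O)Nc2ccc(OC(F)(F)F)cc2)c2ccccc2n1` differs from compound 3 by trifluoromethoxy in place of methylsulfanyl on an aromatic carbon. For the measured compounds named here, no measured step involves a trifluoromethoxy group, and nothing among compounds 1 to 3 moves beyond the scatter in this assay; a step of a 1.0-fold higher number from compound 3 to compound 4 (0.02 log units; within the scatter) is therefore expected, none beyond the scatter. Compound 4 is estimated at 25000 nM in this assay, between 10000 nM and 60000 nM.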

Compound 4, half-maximal effective concentration: 14000 nM
Compound 4: middle estimate off by 1.8-fold (0.25 log units), on the high side; measured number inside the range.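

In this assay the step is a 1.7-fold lower number from compound 3 to compound 4 (0.23 log units; within the scatter) and so trifluoromethoxy and methylsulfanyl on this aromatic carbon, para to a large group, read alike. Against acetyl and carboxy the readings are an at least 1.7-fold lower number from compound 2 to compound 4 (0.25 log units; that floor lies within the scatter) and an at least 1.7-fold lower number from compound 1 to compound 4 (0.25 log units; that floor lies within the scatter) and neither separates the pair it describes. These stay floors because the values behind them include a limit: the limit of > 25000 nM in this assay, at which 2 of the 4 values shown sit. From the compounds shown here alone, whether an amine or a longer chain at this position moves the number beyond the scatter stays open. So does the effect of any change on the shared core.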